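Swapping Cyclohexyl for Methyl: Expected Effect on Cytotoxicity

This account rests on a few compounds, and the source may have more. Where it says the series, first, only, none or still open, it means among the compounds named here.

Compound 1 `CCC(=O)Nc1ccc(-c2nc3cc(C(F)(F)F)ccc3n2C2CCCCC2)cc1` was tested in an ADME assay on BHK cells (Mesocricetus auratus) for cytotoxicity, read by MTT assay, with a stated time of 96 h (on this read-out lower numbers stand for higher toxicity in this test and higher numbers for lower toxicity in this test), where compound 1 gives 15000 nM. Among the three compounds measured so far, compound 1 is the only one for which a number rather than a limit came out. Compound 2 `COc1ccc(-c2nc3cc(C(C)=O)ccc3[nH]2)c(OC)c1` reaches the limit of this assay, giving > 100000 nM. Compound 3 `COc1ccc(-c2nc3cc(C(F)(F)F)ccc3[nH]2)cc1` likewise reaches that limit, giving > 100000 nM. Going by the values given here, compound 1 thus stands apart from the limit of > 100000 nM in this assay, at which 2 of the 3 values shown sit, as the one compound whose toxicity was strong enough to be put into a number.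

Compound 4 `CCC(=O)Nc1ccc(-c2nc3cc(C(F)(F)F)ccc3n2C)cc1` has not yet been measured in this assay. It differs from compound 1 in a single place: methyl in place of cyclohexyl on an aromatic nitrogen. Among the compounds with values here, no two measured compounds here differ in just one place, so no measured step gives a direct guide to how large this change might be. A bulky six-carbon ring is traded for a single carbon, and the expectation is a step toward lower toxicity, of a size estimated as a 2.7-fold higher number from compound 1 to compound 4 (0.43 log units; beyond the scatter), possibly beyond the usual scatter. Compound 4 is therefore expected to give 40000 nM in this assay, within a range from 12000 nM to 100000 nM.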

Compound 4, half-maximal cytotoxic concentration: > 100000 nM
Compound 4 was reported as a limit (the forecaster's own chance of this, stated with the estimate: 30%); at least 2.5-fold (0.39 log units) between middle value and limit.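

Methyl in place of cyclohexyl on this aromatic nitrogen is the first change here that can be read as a single step, with the rest of the molecule left as it is, and in this assay it gives an at least 6.6-fold higher number from compound 1 to compound 4 (0.82 log units; beyond the scatter). So the one compound with a measurable cytotoxic concentration loses that measurable value when only this group is exchanged, which shows that what sits on this nitrogen can matter in this test. Compound 4 gives > 100000 nM, which is a limit and not a number, and the true size of the step stays unknown because compound 4 joins the other compounds at that limit: the limit of > 100000 nM in this assay, at which 3 of the 4 values shown sit.

The compounds shown do not tell whether an ethyl group, a longer chain such as butyl, or a smaller ring such as cyclopentyl on this nitrogen would keep a measurable value, so a gradual fall with shrinking group cannot be told apart from a sharp drop once cyclohexyl leaves. Also open, going by these compounds, is whether the same exchange would have a similar outcome with a nitrile in place of the trifluoromethyl on the shared core.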